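Benzylamine tail variation in the bis(trifluoromethyl)sulfonamide series

The compounds below may be only part of what the source reports. "The series", "measured", "known", "first", "only" and "open" are said of these compounds alone.

Three members of the series have been measured in a functional assay on A2780 cells (Homo sapiens) for inhibition, read by MTT assay, with a stated time of 72 h; on this read-out higher numbers stand for weaker inhibition of growth and lower numbers for stronger inhibition of growth. Compound 1 `O=S(=O)(NCCNCc1ccc(-c2ccccc2)cc1)c1cc(C(F)(F)F)cc(C(F)(F)F)c1` gives 2600 nM, compound 2 `O=S(=O)(NCCCNCc1ccc(C(F)(F)F)cc1)c1cc(C(F)(F)F)cc(C(F)(F)F)c1` gives 2800 nM, and compound 3 `O=S(=O)(NCCCNCc1ccc(-c2ccccc2)cc1)c1cc(C(F)(F)F)cc(C(F)(F)F)c1` gives 2600 nM. The three numbers sit within the scatter of one another, so compound 2 is not set apart from compound 1 or compound 3 in this assay.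

Compound 4 `O=S(=O)(NCCCNCc1ccc(Cl)c(Cl)c1)c1cc(C(F)(F)F)cc(C(F)(F)F)c1` is the next point. Relative to compound 2 the change is 3,4-dichlorophenyl in place of 4-(trifluoromethyl)phenyl on a saturated chain carbon bound to an amine nitrogen. Among the compounds with values here, the only measured step on the same part of the molecule is the one from compound 2 to compound 3, which came to a 1.1-fold lower number from compound 2 to compound 3 (0.03 log units; within the scatter); a second exchange of the group on the same saturated chain carbon has no measured counterpart. Given that step, the expected outcome for compound 4 is a step of no change at the digits printed from compound 2 to compound 4 (within the scatter), that is, nothing beyond the scatter in either direction. Compound 4 is therefore estimated at 2800 nM in this assay, with a range from 1200 nM to 6500 nM.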

Compound 4, concentration for 50% growth inhibition: 1500 nM
Beside the measured number, compound 4's estimate is 1.9-fold (0.27 log units) above it; the measured number falls inside the stated range.
By their numbers in this assay, from the lowest: compounds 4, 1, 3 and 2 (each within the scatter of the next).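

In this assay, a 1.9-fold lower number from compound 2 to compound 4 (0.27 log units; within the scatter), so replacing 4-(trifluoromethyl)benzyl with 3,4-dichlorobenzyl does not separate the two compounds, even though this is the largest step recorded so far at this place. Taken with a 1.1-fold lower number from compound 2 to compound 3 (0.03 log units; within the scatter), the result extends the flat picture at the saturated chain carbon bound to an amine nitrogen from a phenyl exchange to a chlorine-bearing aromatic ring, with no step at this place yet beyond the scatter. No supporting data bear on this result, so it remains an observation without an assigned cause.

Still open, from the compounds shown here alone, is whether any group at this place can move the number beyond the scatter, for example a benzyl group carrying a carboxylic acid or an amine. Going by these compounds, it is equally open whether a longer chain on the sulfonamide nitrogen would do so.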